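A few compounds are considered here, and "the series" means these few. Any claim that something is new, unique, unknown or untested is made for them only; others in the source may bear on it.

Measured compounds in this series:
compound 1, `Cc1ccc2[nH]c(C(=O)N[C@H]3CCN(S(=O)(=O)c4cccnc4)C[C@@H]3C(=O)NCCN(C)C)cc2c1`, 5 uL/min
compound 2, `Cc1ccc2[nH]c(C(=O)N[C@H]3CCN(S(=O)(=O)C4CC4)C[C@@H]3C(=O)NCCN(C)C)cc2c1`, 7 uL/min
compound 3, `Cc1ccc2[nH]c(C(=O)N[C@H]3CCN(S(=O)(=O)N4CCOCC4)C[C@@H]3C(=O)NCCN(C)C)cc2c1`, 6 uL/min

All three numbers come from an ADME assay on cells (Hepatocyte, Rattus norvegicus) for metabolic stability; on this read-out higher numbers stand for fast clearance and lower numbers for slow clearance. Compound 3 sits within the scatter of both neighbours: the step of a 1.2-fold higher number from compound 1 to compound 3 (0.08 log units; within the scatter) and the step of a 1.2-fold lower number from compound 2 to compound 3 (0.07 log units; within the scatter) are both small, so nothing separates the three compounds on this read-out.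

Compound 4 is `Cc1ccc2[nH]c(C(=O)N[C@H]3CCN(C(=O)c4cccnc4)C[C@@H]3C(=O)NCCN(C)C)cc2c1`, not yet measured in this assay. Its change from compound 3 is (pyridin-3-yl)carbonyl in place of (morpholin-4-yl)sulfonyl on an amine nitrogen in a ring. Among the measured compounds shown here, no measured step exchanges the sulfonyl group itself; the measured steps only swap the group on the sulfonyl sulfur, and a 1.2-fold higher number from compound 1 to compound 3 (0.08 log units; within the scatter) shows that pyridin-3-yl on that sulfur, as in compound 1, gives a number within the scatter of compound 3. The pyridin-3-yl group of compound 4 is therefore represented in the set, but its carbonyl linkage is not, so the expectation rests on the flatness of the steps seen so far.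

Compound 4 is expected to give about 7 uL/min in this assay, with a range from 3 uL/min to 16 uL/min. This estimate means a step of a 1.2-fold higher number from compound 3 to compound 4 (0.07 log units; within the scatter), expected to lie within the scatter.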

Compound 4, intrinsic clearance in a liver preparation (reported as CLH), per the amount of preparation that the assay uses: 6 uL/min
The estimate for compound 4 lay 1.2-fold (0.07 log units) above the measured number; low and high end bracket the measured number.
By their numbers in this assay, from the lowest: compounds 1, 3, 4 and 2 (each within the scatter of the next).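

Among the compounds shown here, on the amine nitrogen in the ring, this assay now gives a reading for the linkage itself: (pyridin-3-yl)carbonyl in place of (pyridin-3-yl)sulfonyl gives a 1.2-fold higher number from compound 1 to compound 4 (0.08 log units; within the scatter), the one step here that alters the linkage and keeps the pyridin-3-yl group. The steps from the other two sulfonyl groups read alike, with no change at the digits printed from compound 3 to compound 4 (within the scatter) for (morpholin-4-yl)sulfonyl and a 1.2-fold lower number from compound 2 to compound 4 (0.07 log units; within the scatter) for cyclopropylsulfonyl, so the carbonyl form and the three sulfonyl forms are not separated on this read-out. No supporting data are available to explain this flatness.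

Still open, going by these compounds, is whether any group on this nitrogen moves the number beyond the scatter, for example a simple alkyl chain or a group carrying a carboxylic acid, given that every group here joins through a sulfonyl or a carbonyl. On these data alone, the (2-(dimethylamino)ethyl)carbamoyl group is also common to all four compounds, and its contribution remains unknown without a comparison in which a carboxylic acid or a longer chain stands at that ring atom.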